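The compounds below may be only part of what the source reports. "The series", "measured", "known", "first", "only" and "open" are said of these compounds alone.

Measured compounds:
compound 1, `COc1ccc(F)cc1Nc1cc(NC(=O)Nc2c(Cl)cccc2Cl)ncn1`, 85.5%
compound 2, `COc1cc(NC(=O)Nc2cc(Nc3ccc(C)c(F)c3)ncn2)cc(OC)c1`, 77.5%

The two compounds were tested in a functional assay on PC-9 cells (Homo sapiens) for inhibition, read by MTT assay, with a stated time of 48 h, tested at 10 uM; a lower number here means less inhibition, a higher number more inhibition at the concentration tested (going by the name of the read-out). Compound 1 gives 85.5%, and compound 2 gives 77.5%. Compound 2 stands as the lower of the two numbers, yet its nearest neighbour is compound 1, whose value lies within the usual scatter, so the two readings cannot be told apart with any confidence, and neither number can be called the higher on this evidence.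

The step of interest leads from compound 2 to compound 3, `COc1cc(NC(=O)Nc2cc(Nc3cc(I)ccc3OC)ncn2)cc(OC)c1`, which has not yet been measured in this assay. The change is 5-iodo-2-methoxyphenyl in place of 3-fluoro-4-methylphenyl on a nitrogen on an aromatic ring. Among the compounds with values here, no measured pair in this set shares that difference, so there is no directly comparable step to lean on. Both measured compounds sit high in this assay, and compound 1 already reaches 85.5% with an arrangement of the same kind on that nitrogen, so a step from compound 2 to compound 3 of no size beyond the scatter, or a modest rise, is expected, that is a number 3.5 percentage points higher from compound 2 to compound 3 (within the scatter). Compound 3 is therefore estimated at 81%, within a range of 66% to 93%.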

Compound 3, a percentage reported as inhibition, at one concentration (the size of the read-out at that concentration, not a potency): 91%
Beside the measured number, compound 3's estimate is 10 percentage points below it; the measured number falls inside the stated range.
By their numbers in this assay, from the lowest: compounds 2, 1 and 3 (each within the scatter of the next, the first and the last beyond it).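

In this assay, within the data shown here, the replacement of 3-fluoro-4-methylphenyl by 5-iodo-2-methoxyphenyl on this nitrogen gives a number 13.5 percentage points higher from compound 2 to compound 3 (beyond the scatter) and is the first step in the set that can be read, showing that the reading responds to the aryl group at this position. The entering group brings an iodine and a methoxy group together and carries one hydrogen-bond acceptor where the leaving group carries none, so this single step cannot assign the rise to either substituent. The compounds shown offer no measurement that accounts for the rise.

As far as these compounds go, it remains open whether the iodo or the methoxy group alone would give a comparable reading, and whether either substituent could be exchanged at its place on the ring, for instance a chloro group for the iodo group or an ethoxy group for the methoxy group. Also open, from the compounds shown here alone, is how far this position extends beyond aryl groups, such as to a morpholine or a piperidine ring in place of the 5-iodo-2-methoxyphenyl group, since a reading at one concentration gives no potency.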